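A few compounds are considered here, and "the series" means these few. Any claim that something is new, unique, unknown or untested is made for them only; others in the source may bear on it.

Compound 1, `COc1nc(C(C)(C)C)ccc1[C@@H](c1ccccc1)[C@@](O)(CCN(C)C)c1cccc2ccccc12`: > 64 ug/mL
Compound 2, `COc1nc(-c2ccc(C#N)cc2)ccc1[C@@H](c1ccccc1)[C@@](O)(CCN(C)C)c1cccc2ccccc12`: > 64 ug/mL

In a toxicity assay on HeLa cells (Homo sapiens) for cytotoxicity (a higher number here means that more compound is tolerated, a lower number that less compound is tolerated), compound 2 gives > 64 ug/mL, which is a limit of the assay rather than a number. Compound 1 likewise sits only at a limit. The step that the two limits leave unreadable from compound 1 to compound 2 is therefore unreadable, and the whole picture rests on (the limit of > 64 ug/mL in this assay, at which 2 of the 2 values shown sit). Compound 3, `COc1nc(-c2ccccc2Cl)ccc1[C@@H](c1ccccc1)[C@@](O)(CCN(C)C)c1cccc2ccccc12`, carries 2-chlorophenyl in place of 4-cyanophenyl on an aromatic carbon. Going by the values given here, no measured step speaks to this change, so no shift beyond the scatter is assumed, and the step that the limit leaves unreadable from compound 2 to compound 3 is an expectation only. Compound 3 is estimated at 80 ug/mL, with a range from 40 ug/mL to 160 ug/mL.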

Compound 3, half-maximal cytotoxic concentration: > 64 ug/mL
Compound 3: no number, only a limit; the forecaster's own chance of this, stated with the estimate: 70%; the middle value lies beyond the limit too.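

Going by these compounds alone, no step among compound 1, compound 2 and compound 3 can be read, because each gives only a limit in this assay: the limit of > 64 ug/mL in this assay, at which 3 of the 3 values shown sit. The compounds shown leave open how much of each compound the cells tolerate, and whether swapping these groups changes it at all.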